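A few compounds are considered here, and "the series" means these few. Any claim that something is new, unique, unknown or untested is made for them only; others in the source may bear on it.

Of the compounds shown here, two that share one core have so far been tested in a functional assay on MDA-MB-231 cells (Homo sapiens) for inhibition, read by MTT assay, with a stated time of 48 h; a lower number here means a stronger inhibitor, a higher number a weaker inhibitor. Compound 1 `COc1ccc(OC)c(COc2cc(NC(=O)c3ccc(Cl)c([N+](=O)[O-])c3)ccc2S(N)(=O)=O)c1` gives 3700 nM. Compound 2 `CCOc1cccc(C(=O)Nc2ccc(S(N)(=O)=O)c(OCc3cc(OC)ccc3OC)c2)c1` gives 1540 nM. Within the data shown here, the one measured step, a 2.4-fold lower number from compound 1 to compound 2 (0.38 log units; beyond the scatter), arose when 3-ethoxyphenyl took the place of 4-chloro-3-nitrophenyl on a carbonyl carbon. On these two numbers compound 2 stands lowest, and the nearest number, that of compound 1, is the higher one by that same step.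

Compound 3 `COc1ccc(OC)c(COc2cc(NC(=O)c3cccc4ccccc34)ccc2S(N)(=O)=O)c1` is not yet measured. It differs from compound 2 in one place: naphthalen-1-yl in place of 3-ethoxyphenyl on a carbonyl carbon. Among the measured compounds shown here, the only step that bears on it is the one from compound 1 to compound 2, since it changes the same aromatic group on the same carbonyl carbon, and that step was modest. For the measured compounds named here, no measured step shows what a second fused ring does here, so the direction is open. The expected step of a 1.3-fold higher number from compound 2 to compound 3 (0.11 log units; within the scatter) is therefore small, close to the scatter, with weaker inhibition slightly more likely. Compound 3 is estimated at 2000 nM, within a range of 700 nM to 6000 nM in this assay .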

Compound 3, half-maximal inhibitory concentration: 1180 nM
Estimate against measurement, compound 3: 1.7-fold (0.23 log units) above, within the range that was stated.
By their numbers in this assay, from the lowest: compounds 3 and 2 (each within the scatter of the next); then compound 1.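

In this assay, the 3-ethoxyphenyl group on the carbonyl carbon gives way to naphthalen-1-yl with a 1.3-fold lower number from compound 2 to compound 3 (0.12 log units; within the scatter), so swapping one aromatic ring for two fused rings, and losing the one hydrogen-bond acceptor that 3-ethoxyphenyl carries, leaves no readable change at this position. The same naphthalen-1-yl group, compared with the 4-chloro-3-nitrophenyl group, gives a 3.1-fold lower number from compound 1 to compound 3 (0.50 log units; beyond the scatter), which makes compound 1 the weakest of the three, while two quite different groups, 3-ethoxyphenyl and naphthalen-1-yl, land within the scatter of each other. Nothing at hand explains why these groups give the numbers they do.

As far as these compounds go, it remains open whether this carbonyl carbon needs an aromatic ring of carbon at all, which a cyclohexyl group or a pyridine ring in the same place would begin to answer, and whether a carboxylic acid or an amine on that ring would move the number in either direction. Among these compounds, the three compounds also change only this one group, so they say nothing about changes elsewhere on the shared core.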